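Notes on a lactone fragment series against L1210 cells

This account rests on a few compounds, and the source may have more. Where it says the series, first, only, none or still open, it means among the compounds named here.

Measured compounds:
Compound 1 `C=C(Br)C(=O)Nc1ccc2sc(C(=O)NCCNC(=O)c3cc(OCC4(c5ccc(Cl)cc5)CC(=C)C(=O)O4)nn3C)cc2c1` gives 260 nM in a functional assay on L1210 cells (Mus musculus) for antiproliferative activity; on this read-out lower numbers stand for stronger inhibition and higher numbers for weaker inhibition.
Compound 3 `C=C(Br)C(=O)Nc1ccc2sc(C(=O)O)cc2c1` gives 4500 nM in this assay.
Compound 2 `C=C1CC(COc2cc(C(=O)O)n(C)n2)(c2ccc(Cl)cc2)OC1=O` gives > 10000 nM in this assay; this is a limit of the assay, not a number.

Compound 2 therefore stands at the limit of > 10000 nM in this assay, at which 1 of the 3 values shown sits, and nothing more than that limit is known for it. Compound 4 `C=C1CC(C)(COc2cc(C(=O)O)n(C)n2)OC1=O` differs from compound 2 only at one point: methyl in place of 4-chlorophenyl on a saturated ring carbon. For the measured compounds named here, no measured step of this kind exists among the three compounds above, so the expected step that the limit leaves unreadable from compound 2 to compound 4 in this assay is none beyond the scatter, with the value again most likely reported only as a limit. Compound 4 is estimated at 20000 nM, with a range from 8000 nM to 60000 nM.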

Compound 4, half-maximal inhibitory concentration: > 10000 nM
Compound 4: only a limit was reported; the forecaster's own chance of this, stated with the estimate: 85%; the middle value does not contradict the limit.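

Compound 2 and compound 4 are both reported only as limits in this assay, so no step can be read for methyl in place of 4-chlorophenyl: the limit of > 10000 nM in this assay, at which 2 of the 4 values shown sit.

As far as these compounds go, how far either compound lies past that limit, and whether the two groups differ at all here, stays open.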